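The compounds below may be only part of what the source reports. "The series", "measured", "known", "first", "only" and "open" are said of these compounds alone.

Three compounds share one core and differ only in the group carried on an amide-type nitrogen. Compound 1 `Cc1noc(C)c1-c1cnc(N)c(Oc2ccc(C(=O)NC3CCCC3)cc2)n1` bears cyclopentyl there, compound 2 `Cc1noc(C)c1-c1cnc(N)c(Oc2ccc(C(=O)Nc3ccc(Cl)cc3)cc2)n1` bears 4-chlorophenyl, and compound 3 `Cc1noc(C)c1-c1cnc(N)c(Oc2ccc(C(=O)Nc3cccc(Cl)c3)cc2)n1` bears 3-chlorophenyl. In a functional assay on HepG2 cells (Homo sapiens) for inhibition, read by MTT assay, with a stated time of 72 h (a higher number here means a weaker inhibitor, a lower number a stronger inhibitor), compound 1 gives 12800 nM, compound 2 gives 14400 nM, and compound 3 gives 7300 nM. Compound 3 has the lowest number of the three, yet both gaps to it lie within the scatter: the change a 1.8-fold lower number from compound 1 to compound 3 (0.24 log units; within the scatter) and the change a 2.0-fold lower number from compound 2 to compound 3 (0.30 log units; within the scatter) are both small, as is a 1.1-fold higher number from compound 1 to compound 2 (0.05 log units; within the scatter).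

Compound 4 `Cc1noc(C)c1-c1cnc(N)c(Oc2ccc(C(=O)Nc3cc(Cl)ccn3)cc2)n1` is the next step from compound 3: 4-chloropyridin-2-yl in place of 3-chlorophenyl on an amide-type nitrogen. Going by the values given here, no measured step exchanges a carbon-only aromatic ring for one holding a ring nitrogen, so the nearest guidance is the set of changes on this same nitrogen, all of which stayed within the scatter. The expectation for this assay is therefore a step of about a 1.1-fold higher number from compound 3 to compound 4 (0.04 log units; within the scatter), which is to say no clear movement in either direction. Compound 4 is estimated at 8000 nM in this assay, with a range from 3500 nM to 18000 nM.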

Compound 4, half-maximal inhibitory concentration: > 100000 nM
Compound 4: no number, only a limit; the forecaster's own chance of this, stated with the estimate: 5%; at least 12-fold (1.09 log units) between middle value and limit.
By their numbers in this assay, from the lowest: compounds 3, 1 and 2 (each within the scatter of the next). At a limit, above all of these: compound 4.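

In this assay, compound 4 gives no number, only a limit of the assay: the limit of > 100000 nM in this assay, at which 1 of the 4 values shown sits. The earlier changes on this amide-type nitrogen all stayed within the scatter, but the change to 4-chloropyridin-2-yl, which brings a ring nitrogen and one hydrogen-bond acceptor while keeping the heavy-atom count, is a large one, with an at least 13-fold higher number from compound 3 to compound 4 (1.13 log units; beyond the scatter), and the other two pairs also lie beyond the scatter, with an at least 6.9-fold higher number from compound 2 to compound 4 (0.84 log units; beyond the scatter) and an at least 7.8-fold higher number from compound 1 to compound 4 (0.89 log units; beyond the scatter). This position is therefore not indifferent to its group: cyclopentyl, 4-chlorophenyl and 3-chlorophenyl all give values within the scatter of one another, whereas 4-chloropyridin-2-yl breaks clearly away from all three.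

With a single ring containing nitrogen among the compounds shown, the data cannot say whether any ring nitrogen on this amide-type nitrogen has this effect or only this particular chlorinated ring does. A plain pyridin-2-yl group, or a 4-methoxypyridin-2-yl group carrying methoxy instead of chlorine, would be the kind of neighbour needed to separate the ring nitrogen's part from that of the chlorine.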